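Moving a Fluorine Around a Phenyl Ring, Repeated

The source may report more compounds than this note shows. Statements on the series, on what has been measured and on what is new or still open speak of the compounds shown alone.

Of the compounds shown here, three sharing one core have been tested in a functional assay on HT-29 cells (Homo sapiens) for cytotoxicity, read by MTT assay, with a stated time of 72 h; a higher number here means a weaker inhibitor, a lower number a stronger inhibitor. Compound 1 `COc1cc2c(Oc3ccc(NC(=O)c4cc(-c5ccc(F)cc5)ccn4)cc3F)ccnc2cc1OCCCN1CCCCC1` gives 1370 nM in this assay. Compound 2 `COc1cc2c(Oc3ccc(NC(=O)c4cc(-c5ccccc5F)ccn4)cc3F)ccnc2cc1OCCCN1CCCCC1` gives 320 nM, and compound 3 `COc1cc2c(Oc3ccc(NC(=O)c4cc(-c5ccc(F)cc5)ccn4)cc3F)ccnc2cc1OCCCN1CCCC1` gives 430 nM.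

The difference between compound 1 and compound 2 is 2-fluorophenyl in place of 4-fluorophenyl on an aromatic carbon. This change produced a 4.3-fold lower number from compound 1 to compound 2 (0.63 log units; beyond the scatter), so the fluorine sitting on a different carbon of the outer phenyl ring was enough to make a clear difference in this assay.

Compound 3 differs from compound 1 in another part of the molecule: pyrrolidin-1-yl in place of piperidin-1-yl on a saturated chain carbon, three bonds along the chain from an oxygen on an aromatic ring. That change alone gave a 3.2-fold lower number from compound 1 to compound 3 (0.50 log units; beyond the scatter). Compound 3 and compound 2 stand close to each other, and their values fall within the usual scatter, so no order between them can be claimed.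

Compound 4 `COc1cc2c(Oc3ccc(NC(=O)c4cc(-c5ccccc5F)ccn4)cc3F)ccnc2cc1OCCCN1CCCC1` has not yet been measured. It differs from compound 3 by 2-fluorophenyl in place of 4-fluorophenyl on an aromatic carbon. This is the same change that turned compound 1 into compound 2, placed on the same aromatic carbon, with the two cores differing only in the ring at the end of the chain as described above. If the change carries over from one core to the other, compound 3 to compound 4 is expected to give a step of about a 3.3-fold lower number from compound 3 to compound 4 (0.52 log units; beyond the scatter), resting on a 4.3-fold lower number from compound 1 to compound 2 (0.63 log units; beyond the scatter) as the only direct precedent. Allowing for the possibility that the two changes do not add up fully, compound 4 is estimated at 130 nM in this assay, with a likely range from 50 nM to 350 nM.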

Compound 4, half-maximal inhibitory concentration: 230 nM
Compound 4: the middle estimate sits 1.8-fold (0.25 log units) below what was measured; the measured number falls inside the stated range.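

On the core of compound 3 in this assay, 2-fluorophenyl in place of 4-fluorophenyl gave a 1.9-fold lower number from compound 3 to compound 4 (0.27 log units; within the scatter) and, although this step alone does not separate the two compounds, its size cannot be told apart from that of the earlier step: the same change on two cores in this assay, a 4.3-fold lower number (0.63 log units; beyond the scatter) from compound 1 to compound 2 and a 1.9-fold lower number (0.27 log units; within the scatter) from compound 3 to compound 4, 2.3-fold (0.36 log units) apart, within the scatter of two such steps. With the 2-fluorophenyl group in place, pyrrolidin-1-yl in place of piperidin-1-yl gave a 1.4-fold lower number from compound 2 to compound 4 (0.14 log units; within the scatter) and, again, the two steps for this change cannot be told apart: the same change on two cores in this assay, a 3.2-fold lower number (0.50 log units; beyond the scatter) from compound 1 to compound 3 and a 1.4-fold lower number (0.14 log units; within the scatter) from compound 2 to compound 4, 2.3-fold (0.36 log units) apart, within the scatter of two such steps. The results are therefore compatible with each change carrying over from one core to the other, but they do not prove it, since both new steps lie within the scatter while both earlier ones lie beyond it, and a single pair of cores is too little to support a general rule for the series.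

The compounds shown leave open whether the same picture would hold with a different amine at the end of the chain, such as a dimethylamino group, or with a longer chain. They also leave open how a plain phenyl group or a chlorophenyl group would behave in place of the fluorophenyl groups on either core.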